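This account rests on a few compounds, and the source may have more. Where it says the series, first, only, none or still open, it means among the compounds named here.

Measured in an ADME assay on the whole organism for pharmacokinetics, with Canis familiaris (Canis lupus familiaris) as the target, read by LC-MS, at a dose of 3 mg/kg by the oral route; on this read-out higher numbers stand for higher oral bioavailability and lower numbers for lower oral bioavailability:
- compound 1 `Cc1cc(C(=O)N[C@H]2CCCCC/C=C\[C@@H]3C[C@@]3(C(=O)NS(=O)(=O)C3CC3)NC(=O)[C@@H]3C[C@@H](Oc4nc5ccccc5nc4C)CN3C2=O)no1`: 13%
- compound 2 `Cc1cc(C(=O)N[C@H]2CCCCC/C=C\[C@@H]3C[C@@]3(C(=O)NS(=O)(=O)C3CC3)NC(=O)[C@@H]3C[C@@H](Oc4nc5cc(F)ccc5nc4C)CN3C2=O)no1`: 123%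
- compound 3 `Cc1cc(C(=O)N[C@H]2CCCCC/C=C\[C@@H]3C[C@@]3(C(=O)NS(=O)(=O)C3CC3)NC(=O)[C@@H]3C[C@@H](Oc4nc5ccccc5nc4C(F)(F)F)CN3C2=O)no1`: 200%

Of these three, compound 3 stands highest at 200%. Compound 4 `Cc1cc(C(=O)N[C@H]2CCCCC/C=C\[C@@H]3C[C@@]3(C(=O)NS(=O)(=O)C3CC3)NC(=O)[C@@H]3C[C@@H](Oc4nc5cc(F)ccc5nc4C(F)(F)F)CN3C2=O)no1` differs from it by fluoro in place of hydrogen on an aromatic carbon. The same change gave a large step, a number 110 percentage points higher from compound 1 to compound 2 (beyond the scatter). Trifluoromethyl in place of methyl on an aromatic carbon gave another large step, a number 187 percentage points higher from compound 1 to compound 3 (beyond the scatter). Both steps start from the lowest number, and no measurement shows whether the two changes add up. In this assay, therefore, no step beyond the scatter is expected, and the estimated step is a number 5 percentage points higher from compound 3 to compound 4 (within the scatter). For compound 4 the estimated value is 205%, with an expected range of 120% to 290%.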

Compound 4, oral bioavailability: 74%
Beside the measured number, compound 4's estimate is 131 percentage points above it, outside the stated range (below it).
By their numbers in this assay, from the lowest: compound 1; then compound 4; then compound 2; then compound 3.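

In this assay, fluoro in place of hydrogen on an aromatic carbon has no single direction on these cores, as it now gives a number 126 percentage points lower from compound 3 to compound 4 (beyond the scatter): the same change on two cores in this assay, a number 110 percentage points higher (beyond the scatter) from compound 1 to compound 2 and a number 126 percentage points lower (beyond the scatter) from compound 3 to compound 4, 236 percentage points apart, beyond the scatter of two such steps. Trifluoromethyl in place of methyl on an aromatic carbon reverses as well, giving a number 49 percentage points lower from compound 2 to compound 4 (beyond the scatter): the same change on two cores in this assay, a number 187 percentage points higher (beyond the scatter) from compound 1 to compound 3 and a number 49 percentage points lower (beyond the scatter) from compound 2 to compound 4, 236 percentage points apart, beyond the scatter of two such steps. The effect of each change therefore depends on which group stands at the other place, and the two do not add up in these compounds.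

The compounds shown leave open whether chloro or methoxy on the same aromatic carbon would behave as fluoro does. They also leave open whether an ethyl group in place of the trifluoromethyl would show the same reversal.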